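Moving a halogen: from compound 3 to compound 4

A few compounds are considered here, and "the series" means these few. Any claim that something is new, unique, unknown or untested is made for them only; others in the source may bear on it.

Measured compounds:
- compound 1, `CC(C)(C)N(NC(=O)c1ccccc1)C(=O)c1ccccc1I`, 105 nM
- compound 2, `CCc1ccccc1C(=O)N(NC(=O)c1ccccc1)C(C)(C)C`, 589 nM
- compound 3, `CC(C)(C)N(NC(=O)c1cccc(F)c1)C(=O)c1ccccc1Cl`, 69.2 nM

All three share a core in which two carbonyl groups flank a hydrazide bearing a tert-butyl group. In an assay on cells for agonist activity at ecdysone receptor (Bombyx mori), read by a luciferase reporter, with a stated time of 24 h (on this read-out higher numbers stand for an effect only at larger amounts of compound and lower numbers for an effect already at smaller amounts), compound 3 gives the lowest number of the three; against compound 1 the gap is within the scatter, against compound 2 it is beyond it.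

Compound 4, `CC(C)(C)N(NC(=O)c1ccc(I)cc1)C(=O)c1ccccc1Cl`, differs from compound 3 by 4-iodophenyl in place of 3-fluorophenyl on a carbonyl carbon. Among the compounds with values here, no measured pair changes this part of the molecule. Within the data shown here, the only step on record is a 5.6-fold higher number from compound 1 to compound 2 (0.75 log units; beyond the scatter), a modest change, and it concerns a substituent on the other aromatic ring, so it bears on the present change only loosely: it shows that swapping one small aromatic substituent for another can shift the number beyond the scatter.

For compound 4 a step of a 1.6-fold higher number from compound 3 to compound 4 (0.20 log units; within the scatter) is therefore expected, in either direction but more likely toward a somewhat higher number. Compound 4 is estimated at 110 nM, in the range 30 nM to 400 nM.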

Compound 4, half-maximal effective concentration: 7.59 nM
Estimate against measurement, compound 4: 14-fold (1.16 log units) above, and the stated range ends above it.
By their numbers in this assay, from the lowest: compound 4; then compounds 3 and 1 (each within the scatter of the next); then compound 2.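

Within the data shown here, on this carbonyl carbon, the choice of aromatic ring clearly matters: in this assay, the exchange gives a 9.1-fold lower number from compound 3 to compound 4 (0.96 log units; beyond the scatter), the first step on record at this part of the molecule. The two groups have the same number of heavy atoms and the same kind of ring, so they differ only in which halogen they carry and where it sits on the ring. Nothing measured here explains why the number falls.

As far as these compounds go, whether the step follows the iodine itself or its place on the ring stays open, as the two change together in this single pair. Also open, from the compounds shown here alone, is how the number would respond to an amine, a carboxylic acid or a methoxy group on this ring instead of a halogen.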